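A few compounds are considered here, and "the series" means these few. Any claim that something is new, unique, unknown or untested is made for them only; others in the source may bear on it.

Compound 1 `COc1cc2nc(N3CCN(C(=O)c4ccc(Br)o4)[C@H]4CCCC[C@H]43)nc(N)c2cc1OC` and compound 2 `COc1cc2nc(N3CCN(C(=O)c4ccc(C(C)=O)o4)[C@H]4CCCC[C@H]43)nc(N)c2cc1OC` share one core and differ only in the five-membered ring attached to the carbonyl. In an assay on CHO cells for displacement of a labelled ligand from Alpha-1D adrenergic receptor (Homo sapiens) (on this read-out lower numbers stand for stronger inhibition and higher numbers for weaker inhibition), compound 1 gives 1.55 nM, and compound 2 gives 7.41 nM, the higher of the two numbers; the step between them, a 4.8-fold higher number from compound 1 to compound 2 (0.68 log units; beyond the scatter), lies beyond the scatter. Compound 3 `COc1cc2nc(N3CCN(C(=O)c4cccs4)[C@H]4CCCC[C@H]43)nc(N)c2cc1OC` is the next step from compound 2: thiophen-2-yl in place of 5-acetylfuran-2-yl on a carbonyl carbon. Going by the values given here, only the step from compound 1 to compound 2 bears on this, and it shows that altering the group on that ring shifts the number by a modest amount. Removing the acetyl entirely while exchanging the ring is a wider structural move than that single step, so a somewhat lower number is expected, a 2.5-fold lower number from compound 2 to compound 3 (0.39 log units; beyond the scatter), with the direction resting on one comparison alone. Compound 3 is therefore estimated to give about 3 nM in this assay, within a range from 0.8 nM to 12 nM.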

Compound 3, inhibition constant: 2.34 nM
Compound 3: middle estimate off by 1.3-fold (0.11 log units), on the high side; the range from low to high includes it.
By their numbers in this assay, from the lowest: compounds 1 and 3 (each within the scatter of the next); then compound 2.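

In this assay the exchange of 5-acetylfuran-2-yl for thiophen-2-yl gives a 3.2-fold lower number from compound 2 to compound 3 (0.50 log units; beyond the scatter) and so changes the ring and removes the acetyl in a single move, and the low number is kept without the acetyl. The exchange of 5-bromofuran-2-yl for thiophen-2-yl gives a 1.5-fold higher number from compound 1 to compound 3 (0.18 log units; within the scatter) and so leaves these two groups indistinguishable on this read-out, which means that on this carbonyl carbon a low number does not depend on one particular ring. Nothing measured here explains these numbers.

Going by these compounds, how much of the step away from compound 2 belongs to the ring and how much to the lost acetyl stays open, and plain furan-2-yl would separate the two. Also open, on these data alone, is how an amine or a carboxylic acid on that ring would behave.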